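Swapping cyano for chloro in a small compound series

This account rests on a few compounds, and the source may have more. Where it says the series, first, only, none or still open, it means among the compounds named here.

Compound 1 (`N#Cc1ccc(NC(=O)c2cc(Br)c3cccnc3c2O)cc1`) gives ("not determined" (no result reported))
Compound 2 (`O=C(Nc1ccc(Cl)cc1Cl)c1ccc2cccnc2c1O`) gives (3560 nM)
Compound 3 (`N#Cc1ccc(NC(=O)c2ccc3cccnc3c2O)cc1`) gives (2320 nM)

These compounds were tested in a functional assay on KG-1 cells (Homo sapiens) for cytotoxicity, read by luminescence and CellTiter-Glo, with a stated time of 3 days (a lower number here means a stronger inhibitor, a higher number a weaker inhibitor), and only two of them gave a number. Compound 3 at 2320 nM lies within the usual scatter of compound 2 at 3560 nM so the two cannot be told apart, and compound 1 offers no comparison.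

The next compound is compound 4 (`O=C(Nc1ccc(Cl)cc1)c1ccc2cccnc2c1O`), which has chloro in place of cyano on an aromatic carbon of compound 3. That carbon sits para to a large group. Going by the values given here, no measured pair here shows this swap directly, so the evidence is indirect. Compound 2 also carries chloro and gives 3560 nM in this assay without leaving the scatter of compound 3 (2320 nM). No step beyond the scatter is therefore expected, and the estimated move a 1.3-fold higher number from compound 3 to compound 4 (0.11 log units; within the scatter) is small. The estimate is that compound 4 gives 3000 nM within a range from 1300 nM to 7000 nM when measured.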

Compound 4, half-maximal inhibitory concentration: 3300 nM
For compound 4 the middle estimate is 1.1-fold (0.04 log units) below the measured one, within the range that was stated.
By their numbers in this assay, from the lowest: compounds 3, 4 and 2 (each within the scatter of the next).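

Chloro in place of cyano at this carbon, para to a large group, can now be read directly in this assay: the swap gives a 1.4-fold higher number from compound 3 to compound 4 (0.15 log units; within the scatter) and so cannot be told from no change. Hydrogen in place of chloro on an aromatic carbon can be read for the first time as well, and gives a 1.1-fold lower number from compound 2 to compound 4 (0.03 log units; within the scatter) so this second swap on the same side of the amide cannot be told from no change either. Nothing measured here offers a reason for either result.

As far as these compounds go, it remains open whether other groups on this carbon, such as an amine or a carboxylic acid, would move the number beyond the scatter. The effect of the bromo on the core stays unread, as compound 1 gives "not determined" (no result reported) in this assay and offers no comparison.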